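Amide heteroaryl replacement in a sulfone benzylamide series

A few compounds are considered here, and "the series" means these few. Any claim that something is new, unique, unknown or untested is made for them only; others in the source may bear on it.

Measured so far:
compound 1 `O=C(NCc1ccc(S(=O)(=O)c2cc(F)cc(F)c2)cc1)c1cc2ccncc2o1` — 14 nM
compound 2 `Cn1c(C(=O)NCc2ccc(S(=O)(=O)c3ccccc3)cc2)cc2ccncc21` — 410 nM
compound 3 `O=C(NCc1ccc(S(=O)(=O)c2ccccc2)cc1)c1cc2ccncc2s1` — 7 nM

In an assay for inhibition of Nicotinamide phosphoribosyltransferase (Homo sapiens), read by mass spectrometry, with stated times of 15 min and 30 min (a lower number here means a stronger inhibitor, a higher number a weaker inhibitor), compound 3 gives 7 nM, the lowest of the three numbers. Compound 1 sits close to it, and the two are within the scatter of each other, so no order between them is claimed. Going by the values given here, compound 2, with its own heteroaryl group on the carbonyl, gives a number that lies well beyond the scatter from compound 3; that is the only gap of note among the three, and with only one such pair no general rule can be drawn.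

Compound 4 `O=C(NCc1ccc(S(=O)(=O)c2ccccc2)cc1)c1ccc2nccn2c1` is not yet measured. It differs from compound 3 at the amide: a group of 9 heavy atoms (7 carbon, 2 nitrogen; one five-membered aromatic ring with 2 hetero atoms, one six-membered aromatic ring with 1 hetero atom) in place of a group of 9 heavy atoms (7 carbon, 1 nitrogen, 1 sulfur; one five-membered aromatic ring with 1 hetero atom, one six-membered aromatic ring with 1 hetero atom), on a carbonyl carbon. Among the compounds with values here, no measured pair mirrors this change, so the step can only be expected. Since compound 2 shows that a change of the heteroaryl group on the carbonyl can cost a good deal, a moderate loss is expected, with the step from compound 3 to compound 4 estimated at an 8.6-fold higher number from compound 3 to compound 4 (0.93 log units; beyond the scatter). Compound 4 is expected to give about 60 nM, within 10 nM to 400 nM.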

Compound 4, half-maximal inhibitory concentration: 18 nM
The estimate for compound 4 lay 3.3-fold (0.52 log units) above the measured number; measured number inside the range.
By their numbers in this assay, from the lowest: compounds 3, 1 and 4 (each within the scatter of the next, the first and the last beyond it); then compound 2.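

In this assay, going by these compounds alone, placing the group with a five-membered aromatic ring with 2 hetero atoms on the carbonyl carbon, in place of the sulfur-containing group, gives a 2.6-fold higher number from compound 3 to compound 4 (0.41 log units; beyond the scatter), the first single-place step. The loss is modest, and compound 4 remains at 18 nM, so this position accepts a sulfur-free group with the same heavy-atom count and the same counts of hydrogen-bond donors and acceptors. No measurement available here accounts for the size of this step.

A single step cannot separate the loss of sulfur from the different placement of the ring nitrogens. As far as these compounds go, it also remains open how an amine or a carboxylic acid on the entering group would affect the inhibition of this enzyme.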